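The source may report more compounds than this note shows. Statements on the series, on what has been measured and on what is new or still open speak of the compounds shown alone.

Measured so far in a functional assay on PC-3 cells (Homo sapiens) for cytotoxicity, read by MTT assay; a lower number here means a stronger inhibitor, a higher number a weaker inhibitor:
Compound 1 `Cc1nc(Nc2cccc(Cl)c2)sc1C(=O)/C=C/c1ccccc1` gives > 25000 nM, which is a limit of the assay rather than a number.
Compound 2 `Cc1ccccc1Nc1nc(C)c(C(=O)/C=C/c2ccc(Cl)cc2)s1` gives > 25000 nM, again a limit and not a number.
Compound 3 `Cc1nc(Nc2ccc(Cl)c(Cl)c2)sc1C(=O)/C=C/c1ccccc1` gives 7990 nM.

Within the data shown here, compound 3 therefore holds the only actual number among the three; the other two sit at the limit (the limit of > 25000 nM in this assay, at which 2 of the 3 values shown sit). Among the measured compounds shown here, the one step that can be read is an at least 3.1-fold lower number from compound 1 to compound 3 (0.49 log units; beyond the scatter), in which compound 3 differs from compound 1 only by the chloro groups. The true size of that step is not fixed, since the value for compound 1 is a limit.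

Compound 4 `Cc1ccccc1Nc1nc(C)c(C(=O)/C=C/c2ccccc2)s1` is the next compound, and it differs from compound 3 by 2-methylphenyl in place of 3,4-dichlorophenyl on a nitrogen on an aromatic ring. This removes the group that compound 3 alone carries and brings in the group that compound 2 carries, and compound 2 sits at the limit. Compound 4 is therefore expected to show a step of a 3.8-fold higher number from compound 3 to compound 4 (0.57 log units; beyond the scatter) in this assay, towards a weaker inhibitor, most likely back to the limit. The estimate for compound 4 is 30000 nM, within 10000 nM to 100000 nM.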

Compound 4, half-maximal inhibitory concentration: > 25000 nM
Compound 4 gave a limit, no number; the forecaster's own chance of this, stated with the estimate: 75%; the middle value does not contradict the limit.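

In this assay, the aromatic group on the nitrogen is changed again, and 2-methylphenyl in place of 3,4-dichlorophenyl gives an at least 3.1-fold higher number from compound 3 to compound 4 (0.49 log units; beyond the scatter). Compound 4 gives > 25000 nM, which is a limit of the assay and not a number. Among the compounds shown, only the 3,4-dichlorophenyl group at this position yields a number, while the steps to compound 4 from compound 1 and compound 2 cannot be read, with a limit at both ends: the limit of > 25000 nM in this assay, at which 3 of the 4 values shown sit.

Going by these compounds, the true values behind these limits remain unknown, so the 3-chlorophenyl and 2-methylphenyl groups cannot be ranked against each other. On these data alone, it also remains open whether an aromatic ring carrying an amine or a carboxylic acid in place of the chloro groups would give a number near that of compound 3.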